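Compound 2 to compound 4: the dichlorobenzyl group leaves

The compounds below may be only part of what the source reports. "The series", "measured", "known", "first", "only" and "open" are said of these compounds alone.

In a physicochemical assay for solubility, with a stated time of 24 h, at pH 6.8 (a higher number here means a more soluble compound, a lower number a less soluble compound), compound 2 `O=C(NC[C@@H]1[C@H]2CN(C(=O)NCc3cc(Cl)cc(Cl)c3)C[C@@H]12)c1ccc2[nH]c(=O)oc2c1` gives < 1 ug/mL, which is a limit and not a number. Compound 1 `O=C(NC[C@@H]1[C@H]2CN(C(=O)OCc3cc(Cl)cc(Cl)c3)C[C@@H]12)c1ccc2[nH]c(=O)oc2c1` gives < 1 ug/mL, also a limit. Compound 3 `N#Cc1cc(COC(=O)N2C[C@@H]3[C@@H](CNC(=O)c4ccc5[nH]c(=O)oc5c4)[C@@H]3C2)cc(OC(F)(F)F)c1` gives < 1 ug/mL, again a limit. The record so far is the limit of < 1 ug/mL in this assay, at which 3 of the 3 values shown sit.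

Compound 4 `Cc1cc(COC(=O)N2C[C@@H]3[C@@H](CNC(=O)c4ccc5[nH]c(=O)oc5c4)[C@@H]3C2)no1` is the next to be read, and the change is (5-methyl-1,2-oxazol-3-yl)methoxy in place of (3,5-dichlorobenzyl)amino on a carbonyl carbon. In words, it is (5-methyl-1,2-oxazol-3-yl)methoxy in place of (3,5-dichlorobenzyl)amino on a carbonyl carbon.

Going by the values given here, the only measured step is a step that the two limits leave unreadable from compound 1 to compound 2, with (3,5-dichlorobenzyl)amino in place of (3,5-dichlorobenzyl)oxy on a carbonyl carbon. It offers no size to carry over, so the size expected here is a judgement on the structural change alone. The direction is firmer: with compound 2 at its limit of < 1 ug/mL, any readable number in this assay would lie upward. A step beyond the scatter is expected, although another limit remains possible. The expected change is an at least 12-fold higher number from compound 2 to compound 4 (1.07 log units; beyond the scatter). Compound 4 is estimated at 12 ug/mL, with an expected range of 1.5 ug/mL to 80 ug/mL.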

Compound 4, solubility: 63 ug/mL
Compound 4: middle estimate off by 5.3-fold (0.72 log units), on the low side; the measured number falls inside the stated range.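

Within this assay the carbonyl carbon on the amide-type nitrogen in a ring proves to be a place where a change of substituent lifts the read-out off the floor: (5-methyl-1,2-oxazol-3-yl)methoxy in place of (3,5-dichlorobenzyl)amino gives an at least 63-fold higher number from compound 2 to compound 4 (1.79 log units; beyond the scatter), a large step. The oxygen link need not change for this, since 5-methyl-1,2-oxazol-3-yl in place of 3,5-dichlorophenyl on a saturated chain carbon bound to an oxygen next to a carbonyl group gives an at least 63-fold higher number from compound 1 to compound 4 (1.79 log units; beyond the scatter), equally large. Going by these compounds alone, compound 4 is the only compound here with a readable number, and both steps start from a limit and not from a number: the limit of < 1 ug/mL in this assay, at which 3 of the 4 values shown sit.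

From the compounds shown here alone, the step from compound 1 to compound 2 cannot be read, so the oxygen and nitrogen links stay unranked, and the full size of both large steps stays unknown. Also open, going by these compounds, is whether the higher number belongs to the 5-methyl-1,2-oxazol-3-yl ring itself, or would also come with a pyridin-3-yl ring, or with an aminomethyl group on the 3,5-dichlorophenyl ring.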